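Bromo core with a fluoroindole: a small step expected

The source may hold more compounds than are shown below. What is called first, only, known or untested is meant among the compounds shown, and "the series" means these compounds.

Compound 1 `CO[C@@H]1[C@H](N(C)c2ncc(-c3c[nH]c4ccc(F)cc34)s2)C[C@H]2O[C@]1(C)n1c3ccccc3c3c4c(c5c6ccccc6n2c5c31)C(=O)NC4` gives 510 nM in a functional assay on MV4-11 cells (Homo sapiens) for antiproliferative activity, read by CellTiter-Glo, with a stated time of 72 h; a higher number here means a weaker inhibitor, a lower number a stronger inhibitor.
Compound 2 `CO[C@@H]1[C@H](N(C)c2ncc(-c3c[nH]c4ccc(F)cc34)s2)C[C@H]2O[C@]1(C)n1c3ccccc3c3c4c(c5c6cc(Cl)ccc6n2c5c31)C(=O)NC4` gives 320 nM in this assay.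
Compound 3 `CO[C@@H]1[C@H](N(C)c2ncc(-c3c[nH]c4ccccc34)s2)C[C@H]2O[C@]1(C)n1c3ccccc3c3c4c(c5c6cc(Br)ccc6n2c5c31)C(=O)NC4` gives 360 nM in this assay.

Among these three, compound 3 stands second highest; its nearest neighbour is compound 2, and the furthest is compound 1, and both of those gaps are within the scatter. Going by the values given here, the one single-point step that has been measured, a 1.6-fold lower number from compound 1 to compound 2 (0.20 log units; within the scatter), concerns the chloro substituent on the shared core, not the indole, so it does not bear directly on the change at hand. Compound 2 and compound 3 differ in two places at once, so their values alone cannot be split into a core part and an indole part.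

Compound 4 `CO[C@@H]1[C@H](N(C)c2ncc(-c3c[nH]c4ccc(F)cc34)s2)C[C@H]2O[C@]1(C)n1c3ccccc3c3c4c(c5c6cc(Br)ccc6n2c5c31)C(=O)NC4` is compound 3 with fluoro in place of hydrogen on an aromatic carbon. Among the compounds with values here, no measured pair isolates this fluoro addition, and nothing among the three compounds points to a shift beyond the scatter. For compound 4 in this assay the estimate is 330 nM, with a range from 150 nM to 750 nM. The expected step, a 1.1-fold lower number from compound 3 to compound 4 (0.04 log units; within the scatter), is thus taken to lie within the scatter.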

Compound 4, half-maximal inhibitory concentration: 960 nM
The estimate for compound 4 lay 2.9-fold (0.46 log units) below the measured number; the measured number lies above the stated range.
By their numbers in this assay, from the lowest: compounds 2, 3, 1 and 4 (each within the scatter of the next, the first and the last beyond it).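

On the bromo core, the change from 1H-indol-3-yl to 5-fluoro-1H-indol-3-yl, with fluoro on an aromatic carbon of the six-membered ring, is not neutral in this assay (a step of a 2.7-fold higher number from compound 3 to compound 4 (0.43 log units; beyond the scatter)), so this position responds to a single added fluoro. With the fluoroindole held constant, the halogen on the core also matters: bromo in place of chloro gives a 3.0-fold higher number from compound 2 to compound 4 (0.48 log units; beyond the scatter) and stands beyond the scatter, while bromo in place of hydrogen gives a 1.9-fold higher number from compound 1 to compound 4 (0.27 log units; within the scatter) and stays within it, so the two halogens cannot be treated as interchangeable in this series. No measurement here accounts for either shift.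

On these data alone, whether the fluoro step carries over to the core of compound 1 or compound 2, rather than belonging to the bromo core of compound 3 alone, stays open. So does the response of the same aromatic carbon to other groups, such as a methoxy group, a nitrile or an amine, which would show whether the rise in the number is particular to fluoro.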